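Swapping a catechol amine tail for a hydroxyphenoxy tail

The source may hold more compounds than are shown below. What is called first, only, known or untested is meant among the compounds shown, and "the series" means these compounds.

Compound 1 `Cc1ccc(S(=O)(=O)Nc2ccc3c(c2)C(=O)N(CCNc2ccc(O)c(O)c2)C3=O)cc1` carries a (3,4-dihydroxyphenyl)amino group at the end of a short chain on the shared core. Among the measured compounds shown here, in an assay on isolated protein for inhibition of lysosomal alpha-glucosidase (Rattus norvegicus), read by colorimetric assay (a lower number here means a stronger inhibitor, a higher number a weaker inhibitor), compound 1 gives 28800 nM, the lowest of the two numbers measured so far; its only neighbour is compound 2 `Cc1ccc(S(=O)(=O)Nc2ccc3c(c2)C(=O)N(CCOc2cccc(O)c2)C3=O)cc1`, which in this assay gives 55600 nM. The change from compound 1 to compound 2 was a 1.9-fold higher number from compound 1 to compound 2 (0.29 log units; within the scatter).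

Compound 3 `Cc1ccc(S(=O)(=O)Nc2ccc3c(c2)C(=O)N(CCOc2ccc(O)cc2)C3=O)cc1` has not yet been measured in this assay. It differs from compound 1 in one place: 4-hydroxyphenoxy in place of (3,4-dihydroxyphenyl)amino on a saturated chain carbon, two bonds along the chain from an amide-type nitrogen in a ring. For the measured compounds named here, the only measured step that bears on this change is the one from compound 1 to compound 2, where a 3-hydroxyphenoxy group took the same place; that step stayed within the scatter. Compound 3 makes a closely related swap, so the expectation is a step of about the same size, a 1.7-fold higher number from compound 1 to compound 3 (0.24 log units; within the scatter), toward a somewhat higher number but not clearly beyond the scatter.

For compound 3 the estimated value in this assay is 50000 nM, within a range from 20000 nM to 125000 nM.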

Compound 3, half-maximal inhibitory concentration: 47700 nM
Beside the measured number, compound 3's estimate is 1.0-fold (0.02 log units) above it; low and high end bracket the measured number.
By their numbers in this assay, from the lowest: compounds 1, 3 and 2 (each within the scatter of the next).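

In this assay, a 1.7-fold higher number from compound 1 to compound 3 (0.22 log units; within the scatter) stays within the scatter, so a second hydroxyphenoxy tail on the saturated chain carbon also cannot be told apart from the (3,4-dihydroxyphenyl)amino group. The new comparison is between the two hydroxyphenoxy tails: a 1.2-fold lower number from compound 2 to compound 3 (0.07 log units; within the scatter) is also within the scatter, so 4-hydroxyphenyl and 3-hydroxyphenyl on the oxygen cannot be told apart in these data. All three compounds therefore lie within the scatter of one another, even though the entering 4-hydroxyphenoxy group has 1 hydrogen-bond donor where the leaving group has 3, and no measurement is available that would explain this result.

The steps from compound 1 change the linking nitrogen to an oxygen and alter the ring hydroxyl groups at the same time, so a 3,4-dihydroxyphenoxy tail would be needed to separate those two changes. On these data alone, it also remains open whether a plain phenoxy group with no hydroxyl, a carboxylic acid at the end of the chain, or a longer chain would move the number beyond the scatter.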